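Methyl to Cyclohexyl: Waiting for the Next Number

The source may report more compounds than this note shows. Statements on the series, on what has been measured and on what is new or still open speak of the compounds shown alone.

Measured so far:
- compound 1, `c1coc(-c2nc3nc(NC4CCCCC4)nc(NC4CCCCC4)n3n2)c1`: 129 nM
- compound 2, `CNc1nc(NCc2ccc(F)cc2)n2nc(-c3ccco3)nc2n1`: 557 nM

Both numbers come from an assay on CHO cells for displacement of a labelled ligand from adenosine receptor A3 (Homo sapiens); on this read-out lower numbers stand for stronger inhibition and higher numbers for weaker inhibition. Compound 2 shows the highest of the two values; its nearest neighbour, compound 1, sits clearly lower, and that gap lies beyond the usual scatter of repeated measurements. Compound 1 carries two cyclohexylamino groups on its core, while compound 2 carries a methylamino and a fluorobenzylamino group, so the two differ in more than one place and their values can only be set side by side.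

Compound 3, `Fc1ccc(CNc2nc(NC3CCCCC3)nc3nc(-c4ccco4)nn23)cc1`, has not yet been measured in this assay. It arises from compound 2 by a single change: cyclohexyl in place of methyl on a nitrogen on an aromatic ring. For the measured compounds named here, because compound 1 with its cyclohexylamino groups gives 129 nM while compound 2 gives 557 nM, cyclohexylamino appears compatible with strong binding, and a step toward a lower number is expected, although no directly comparable pair confirms this. The expected step from compound 2 to compound 3 is a 3.7-fold lower number from compound 2 to compound 3 (0.57 log units; beyond the scatter). Compound 3 is estimated to give about 150 nM, with a likely range from 40 nM to 600 nM.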

Compound 3, inhibition constant: 1300 nM
The estimate for compound 3 lay 8.7-fold (0.94 log units) below the measured number, and the stated range ends below it.
By their numbers in this assay, from the lowest: compound 1; then compound 2; then compound 3.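

For the compounds shown here, measured in this assay, cyclohexyl in place of methyl on a nitrogen on an aromatic ring gives a 2.3-fold higher number from compound 2 to compound 3 (0.37 log units; beyond the scatter) and so moves the number up, the opposite direction from the one that the low value of compound 1 had suggested. Putting 4-fluorobenzyl in place of one cyclohexyl on a nitrogen on an aromatic ring gives a 10-fold higher number from compound 1 to compound 3 (1.00 log units; beyond the scatter) and shows that a single cyclohexylamino group does not secure a low number in this set: the lowest number belongs to the compound carrying two of them. Nothing measured here accounts for either rise.

As far as these compounds go, what remains open is how the number changes between the two extremes tried at this nitrogen, for example with an ethyl or cyclopropyl group, which are smaller than cyclohexyl but larger than methyl. It is also unclear whether an unsubstituted benzyl group or a longer chain in place of the 4-fluorobenzyl group would change how cyclohexylamino and methylamino compare.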